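Variation at the amide-bearing chain carbon: compound 4

A few compounds are considered here, and "the series" means these few. Any claim that something is new, unique, unknown or untested is made for them only; others in the source may bear on it.

Compound 1, `NC(=O)C[C@H](NC(=O)CN(c1nc(Cl)nc2[nH]cnc12)C1CC1)C(=O)O`, in a functional assay on the whole organism (Tail, strain ICR) with Mus musculus as the target, in the tail flick test, with a stated time of 60 min, at a dose of 25 umol/kg by the oral route (on this read-out lower numbers stand for a weaker effect and higher numbers for a stronger effect at the one dose given), gives 43.1%.
Compound 2, `O=C(O)CNC(=O)CN(c1nc(Cl)nc2[nH]cnc12)C1CC1`, in this assay gives 38.9%.
Compound 3, `CC(C)[C@H](NC(=O)CN(c1nc(Cl)nc2[nH]cnc12)C1CC1)C(=O)O`, in this assay gives 38.8%.

Compound 3 holds the lowest of the three numbers, but its nearest neighbour is compound 2 and its furthest is compound 1, and both gaps lie within the scatter, so no order among the three can be read from these values.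

Compound 4, `O=C(O)C[C@H](NC(=O)CN(c1nc(Cl)nc2[nH]cnc12)C1CC1)C(=O)O`, is the next member to be measured. It differs from compound 3 in one place: carboxymethyl in place of isopropyl on a saturated chain carbon bound to an amide-type nitrogen and a carbonyl carbon.

Among the compounds with values here, two measured steps bear on this position and both end at compound 3: a number 0.1 percentage points lower from compound 2 to compound 3 (within the scatter) and a number 4.3 percentage points lower from compound 1 to compound 3 (within the scatter). The remaining step, a number 4.2 percentage points lower from compound 1 to compound 2 (within the scatter), lies at the same place. Every change tried so far at this carbon, whether to hydrogen, to isopropyl or to carbamoylmethyl, has left the read-out within the scatter. On that basis no step beyond the scatter is expected for carboxymethyl in place of isopropyl, and the estimated step is a number 1.2 percentage points higher from compound 3 to compound 4 (within the scatter).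

Compound 4 is therefore expected to give about 40%, with a range from 26% to 54%.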

Compound 4, a percentage reported as activity, at one dose (the size of the read-out at that dose, not a potency): 38.9%
Estimate against measurement, compound 4: 1.1 percentage points above; the range from low to high includes it.
By their numbers in this assay, from the lowest: compounds 3, 2, 4 and 1 (each within the scatter of the next).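

Carboxymethyl in place of isopropyl at this carbon, in this assay, adds a carbonyl-bearing acid group to the chain and still gives only a small step (a number 0.1 percentage points higher from compound 3 to compound 4 (within the scatter)), while the same group in place of hydrogen gives (no change at the digits printed from compound 2 to compound 4 (within the scatter)). The position has now taken a hydrogen, a branched hydrocarbon group, a primary amide side chain and a carboxylic acid side chain, and all four compounds lie within the scatter of one another. The new pair also isolates a smaller edit, hydroxy in place of amino on a carbonyl carbon, which turns the carbamoylmethyl side chain into carboxymethyl and likewise stays within the scatter (a number 4.2 percentage points lower from compound 1 to compound 4 (within the scatter)).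

No measurement is at hand that could explain this flat response.

Still open, as far as these compounds go, is whether a side chain with an amine, such as 4-aminobutyl, or with an aromatic ring, such as benzyl, or a longer carboxylic acid chain at this carbon would give a step beyond the scatter. From the compounds shown here alone, with a single dose and a single time for all four compounds, it is also open whether they would separate at other doses or times.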